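The compounds below may be only part of what the source reports. "The series", "measured", "known", "first", "only" and "open" are said of these compounds alone.

Compound 1 `O=C(Nc1ccc(Sc2nc3ccccc3s2)c(Cl)c1)c1cccc(Br)c1O` gives 6900 nM in an assay for inhibition of HSP60/HSP10 (Homo sapiens), with a stated time of 60 min (a lower number here means a stronger inhibitor, a higher number a weaker inhibitor), the lowest of the two numbers in hand. The nearest is compound 2 `O=C(Nc1ccc(Sc2nc3ccccc3s2)cc1)c1cccc(Br)c1O`, which gives 26000 nM in this assay; the change is a 3.8-fold higher number from compound 1 to compound 2 (0.58 log units; beyond the scatter), hydrogen in place of chloro on an aromatic carbon. Compound 3 `O=C(Nc1ccccc1)c1cccc(Br)c1O` reaches only a limit of this assay, > 100000 nM (the limit of > 100000 nM in this assay, at which 1 of the 3 values shown sits). Compound 4 `COc1ccc(Br)cc1C(=O)Nc1ccc(Sc2nc3ccccc3s2)c(Cl)c1` differs from compound 1 by 5-bromo-2-methoxyphenyl in place of 3-bromo-2-hydroxyphenyl on a carbonyl carbon. Among the compounds with values here, no measured step touches this carbonyl substituent, so the single step from compound 1 to compound 2 offers no direct guide; the values of compound 1 and compound 3 show only that stripping the core loses all measurable inhibition. A moderately higher number is expected. Compound 4 is estimated at 20000 nM, between 6000 nM and 70000 nM. The expected step is a 2.9-fold higher number from compound 1 to compound 4 (0.46 log units; beyond the scatter).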

Compound 4, half-maximal inhibitory concentration: > 100000 nM
Compound 4: a limit, no number; the forecaster's own chance of this, stated with the estimate: 20%; at least 5.0-fold (0.69 log units) between middle value and limit.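

With the shared core and the chloro group kept, the carbonyl substituent alone decides whether any inhibition can be read: 5-bromo-2-methoxyphenyl in place of 3-bromo-2-hydroxyphenyl gives an at least 14-fold higher number from compound 1 to compound 4 (1.16 log units; beyond the scatter). Compound 4 stands at a limit of this assay, not at a number: the limit of > 100000 nM in this assay, at which 2 of the 4 values shown sit. The step changes the bromine position and replaces hydroxy with methoxy at once, so it assigns the loss to neither.

Still open, from the compounds shown here alone, is which of the two matters, as 3-bromo-2-methoxyphenyl or 5-bromo-2-hydroxyphenyl would show. Also open, going by these compounds, is whether an amine in place of the hydroxy keeps inhibition.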